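This account rests on a few compounds, and the source may have more. Where it says the series, first, only, none or still open, it means among the compounds named here.

Compound 2 `Cn1c(-c2ccc(N)cc2)nc2cc(C(F)(F)F)ccc21` has the highest number of the two that were measured in an ADME assay on MT4 cells (Homo sapiens) for cytotoxicity, read by MTT assay, with a stated time of 96 h; on this read-out lower numbers stand for higher toxicity in this test and higher numbers for lower toxicity in this test: in this assay compound 2 gives 20000 nM, and the nearest measured compound, compound 1 `Cn1c(-c2ccc(NC(=O)CN3CCN(c4ccccc4)CC3)cc2)nc2cc(C(F)(F)F)ccc21`, gives 1500 nM, a gap beyond the scatter. Compound 3 `CCC(=O)Nc1ccc(-c2nc3cc(C(F)(F)F)ccc3n2C)cc1` differs from compound 2 by one change (propanoyl in place of hydrogen on a nitrogen on an aromatic ring). For the measured compounds named here, no step between measured compounds bears on this change, so only a modest move is expected, toward a lower number, since compound 1 with a larger amide gives 1500 nM. For compound 3 the estimate is 8000 nM, within 3000 nM to 20000 nM, an expected step of a 2.5-fold lower number from compound 2 to compound 3 (0.40 log units; beyond the scatter).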

Compound 3, half-maximal cytotoxic concentration: 8000 nM
Beside the measured number, compound 3's estimate shows no gap at the digits printed; low and high end bracket the measured number.
By their numbers in this assay, from the lowest: compound 1; then compound 3; then compound 2.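

In this assay, propanoyl in place of hydrogen on a nitrogen on an aromatic ring gives a 2.5-fold lower number from compound 2 to compound 3 (0.40 log units; beyond the scatter), so even this short amide lowers the number. With the amide kept, methyl in place of 4-phenylpiperazin-1-yl gives a 5.3-fold higher number from compound 1 to compound 3 (0.73 log units; beyond the scatter), so the amide alone does not account for the low number of compound 1, and the 4-phenylpiperazin-1-yl group goes with a further drop. Nothing available explains either step.

Open, from the compounds shown here alone, is how a longer chain, or an amine or a carboxylic acid at the end of the acyl chain, would compare. Also open, going by these compounds, is whether a sulfonamide on that nitrogen would lower the number as the propanoyl amide does.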